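A Sulfonyl Group Takes the Place of Isobutoxycarbonyl

A few compounds are considered here, and "the series" means these few. Any claim that something is new, unique, unknown or untested is made for them only; others in the source may bear on it.

Three compounds have been measured in an assay on isolated protein for binding affinity to histamine H2 receptor (Homo sapiens); on this read-out higher numbers stand for weaker inhibition and lower numbers for stronger inhibition:

compound 1 `CCCCCC(=O)c1ccc(OCCCN2CCNCC2)cc1`: 14500 nM
compound 2 `CCCCCC(=O)c1ccc(OCCCN2CCN(C(=O)OCC(C)C)CC2)cc1`: 3720 nM
compound 3 `CCCCCC(=O)c1ccc(OCCCN2CCN(C(=O)N3CCOCC3)CC2)cc1`: 17800 nM

Compound 2 shows the lowest number of the three in this assay; its steps to the others, a 3.9-fold lower number from compound 1 to compound 2 (0.59 log units; beyond the scatter) and a 4.8-fold higher number from compound 2 to compound 3 (0.68 log units; beyond the scatter), both lie beyond the scatter, whereas a 1.2-fold higher number from compound 1 to compound 3 (0.09 log units; within the scatter) does not. Compound 4 `CCCCCC(=O)c1ccc(OCCCN2CCN(S(=O)(=O)c3ccc(C#N)cc3)CC2)cc1` differs from compound 2 by (4-cyanophenyl)sulfonyl in place of isobutoxycarbonyl on an amine nitrogen in a ring. The measured steps concern only hydrogen, isobutoxycarbonyl and (morpholin-4-yl)carbonyl at this nitrogen; none involves a sulfonyl or an aromatic ring there, so they bear on the new step only loosely. One substituent helped modestly, the other did not. For compound 4 a step within or just beyond the scatter is expected, a 1.2-fold higher number from compound 2 to compound 4 (0.08 log units; within the scatter). Compound 4 is therefore estimated at 4500 nM in this assay, within a range from 1300 nM to 15000 nM.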

Compound 4, inhibition constant: 12300 nM
Compound 4: the middle estimate sits 2.7-fold (0.44 log units) below what was measured, within the range that was stated.
By their numbers in this assay, from the lowest: compound 2; then compounds 4, 1 and 3 (each within the scatter of the next).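

In this assay the (4-cyanophenyl)sulfonyl group does not keep what isobutoxycarbonyl gained at this ring nitrogen (a 3.3-fold higher number from compound 2 to compound 4 (0.52 log units; beyond the scatter)). Compound 4 instead falls in with the hydrogen and the (morpholin-4-yl)carbonyl group (a 1.2-fold lower number from compound 1 to compound 4 (0.07 log units; within the scatter); a 1.4-fold lower number from compound 3 to compound 4 (0.16 log units; within the scatter)), so that among these four groups only isobutoxycarbonyl stands apart. No measurement at hand bears on the reason for this. The compounds shown leave open whether the sulfonyl or the aromatic ring decides the step, and whether a methylsulfonyl or a benzyloxycarbonyl group at this nitrogen would sit with compound 2 or with compounds 1, 3 and 4.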